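Notes on compound 3, still unmeasured

The source may report more compounds than this note shows. Statements on the series, on what has been measured and on what is new or still open speak of the compounds shown alone.

Values in a functional assay on MCF7 cells (Homo sapiens) for antiproliferative activity, read by CellTiter-Glo, with a stated time of 5 days; a higher number here means a weaker inhibitor, a lower number a stronger inhibitor:
Compound 1 `CC/C(=C(/c1ccc(/C=C/C(=O)O)cc1)c1ccc2cncn2c1)c1ccccc1`: > 500 nM, a limit
Compound 2 `CC/C(=C(/c1ccc(/C=C/C(=O)O)cc1)c1ccc2nncn2c1)c1ccccc1`: > 500 nM, a limit

Compound 2 gives only a limit, not a number, and stands at the limit of > 500 nM in this assay, at which 2 of the 2 values shown sit. Compound 3 `CC/C(=C(/c1ccc(/C=C/C(=O)O)cc1)c1ccc2nnnn2c1)c1ccccc1` differs from compound 2 as follows: a group of 9 heavy atoms (5 carbon, 4 nitrogen; one five-membered aromatic ring with 4 hetero atoms, one six-membered aromatic ring with 1 hetero atom) in place of a group of 9 heavy atoms (6 carbon, 3 nitrogen; one five-membered aromatic ring with 3 hetero atoms, one six-membered aromatic ring with 1 hetero atom), on a double-bonded chain carbon bound to an aromatic carbon and a double-bonded chain carbon. For the measured compounds named here, the one measured exchange at this place is a step that the two limits leave unreadable from compound 1 to compound 2, so no size carries over. No step beyond the scatter, in either direction, is therefore expected in this assay. The expected change is a step that the limit leaves unreadable from compound 2 to compound 3. For compound 3 the estimated value is 800 nM, with an expected range of 350 nM to 2500 nM.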

Compound 3, half-maximal inhibitory concentration: > 500 nM
Compound 3 gave a limit, no number; the forecaster's own chance of this, stated with the estimate: 85%; the middle value is on the limit's open side.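

In this assay compound 3 gives > 500 nM, a limit and not a number, so no step to compound 3 from compound 1 or compound 2 can be read: the limit of > 500 nM in this assay, at which 3 of the 3 values shown sit.

The compounds shown leave open whether these ring exchanges change the activity at all, and by how much; none of the three has a number in this assay.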